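Removing the outer phenyl from compound 1

The compounds below may be only part of what the source reports. "The series", "measured", "known", "first", "only" and "open" are said of these compounds alone.

Among the compounds with values here, compound 1 `CN(C)CCCCCSC1=Nc2ccccc2C(CC(=O)NCc2ccccc2)N1c1ccc(-c2ccccc2)cc1` is one of two compounds measured in an assay on cells for inhibition of Voltage-dependent T-type calcium channel subunit alpha-1G (Homo sapiens), read by patch clamp (on this read-out higher numbers stand for weaker inhibition and lower numbers for stronger inhibition), where compound 1 gives 7770 nM. Within the data shown here, its only measured neighbour is compound 2 `CN(C)CCCCCSC1=Nc2ccccc2C(CC(=O)NCc2ccc(F)cc2)N1c1ccc(-c2ccccc2)cc1`, which in this assay gives 27400 nM; the step of a 3.5-fold higher number from compound 1 to compound 2 (0.55 log units; beyond the scatter) comes from fluoro in place of hydrogen on an aromatic carbon, and compound 1 therefore stands at the lower of the two numbers.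

Compound 3 `CN(C)CCCCCSC1=Nc2ccccc2C(CC(=O)NCc2ccccc2)N1c1ccccc1` differs from compound 1 in another part of the molecule: hydrogen in place of phenyl on an aromatic carbon, on an aromatic carbon of a six-membered aromatic ring of carbon only, para to a large group; cut one bond further out, the same difference reads 4-phenylphenyl to phenyl. Among the measured compounds shown here, no measured step touches this position, since the step from compound 1 to compound 2 concerns the other ring. The expectation can only be rough: the loss of six heavy atoms is a larger change than the single fluoro, so a modest step toward a higher number in this assay is expected, of the order of a 2.6-fold higher number from compound 1 to compound 3 (0.41 log units; beyond the scatter). Compound 3 is accordingly estimated at 20000 nM, within a range of 5000 nM to 80000 nM.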

Compound 3, half-maximal inhibitory concentration: 18500 nM
Beside the measured number, compound 3's estimate is 1.1-fold (0.03 log units) above it, within the range that was stated.
By their numbers in this assay, from the lowest: compound 1; then compounds 3 and 2 (each within the scatter of the next).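

Within the data shown here, the change from 4-phenylphenyl to phenyl is the first measured change on this side of the molecule, as the earlier step from compound 1 to compound 2 concerned the other ring. In this assay, removing the outer phenyl, so that hydrogen stands on an aromatic carbon of a six-membered aromatic ring of carbon only, para to a large group, gives a 2.4-fold higher number from compound 1 to compound 3 (0.38 log units; beyond the scatter). The step is modest for the loss of a whole ring of six heavy atoms, and it shows that this outer phenyl is not required for measurable inhibition, although compound 1 keeps the lower number of this pair; no evidence is available to explain the size or direction of this step.

The compounds shown leave open whether a single substituent at this place, such as a chlorine atom or a methoxy group, or an outer pyridine ring in place of the phenyl, would return the number to that of compound 1 or move it further. They also leave open whether fluoro on the benzyl ring of the amide would give a similar step on the phenyl compound 3.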